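The compounds below may be only part of what the source reports. "The series", "measured", "known", "first", "only" and "open" are said of these compounds alone.

Of the compounds shown here, three that share one core have been tested in a functional assay on EC9706 cells (Homo sapiens) for antiproliferative activity, read by MTT assay, with a stated time of 72 h; a higher number here means a weaker inhibitor, a lower number a stronger inhibitor. Compound 1 `CCN(CC)C(=S)SCC1=CCOC1=O` gives 136000 nM. Compound 2 `CCNC(=S)SCC1=CCOC1=O` gives 44400 nM. Compound 3 `CN(C)C(=S)SCC1=CCOC1=O` gives 182000 nM, the highest of the three numbers; the two measured steps that end at it are a 1.3-fold higher number from compound 1 to compound 3 (0.13 log units; within the scatter) and a 4.1-fold higher number from compound 2 to compound 3 (0.61 log units; beyond the scatter).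

Compound 4 `CNC(=S)SCC1=CCOC1=O` is the next step from compound 3. The change is hydrogen in place of methyl on an amide-type nitrogen. Among the measured steps, the closest parallel is the same exchange carried out with an ethyl group instead of the methyl, which gave a 3.1-fold lower number from compound 1 to compound 2 (0.49 log units; beyond the scatter). The step in which dimethylamino replaced diethylamino on the thiocarbonyl carbon gave a 1.3-fold higher number from compound 1 to compound 3 (0.13 log units; within the scatter), so the length of the alkyl group on that nitrogen made little difference, and the methyl-to-hydrogen exchange in compound 4 is expected to behave much like the ethyl-to-hydrogen one. For compound 4 the expected step is a 3.0-fold lower number from compound 3 to compound 4 (0.48 log units; beyond the scatter), toward a lower number and therefore a stronger inhibitor. Compound 4 is accordingly estimated at 60000 nM, with a range from 25000 nM to 150000 nM.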

Compound 4, half-maximal inhibitory concentration: 85400 nM
The estimate for compound 4 lay 1.4-fold (0.15 log units) below the measured number; the measured number falls inside the stated range.
By their numbers in this assay, from the lowest: compounds 2, 4, 1 and 3 (each within the scatter of the next, the first and the last beyond it).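

In this assay, the exchange of a methyl for hydrogen on the amide-type nitrogen, which turns dimethylamino into methylamino, gives a 2.1-fold lower number from compound 3 to compound 4 (0.33 log units; beyond the scatter) and goes the same way as the ethyl-to-hydrogen exchange, a 3.1-fold lower number from compound 1 to compound 2 (0.49 log units; beyond the scatter) and so lowers the number in both of the pairs shown. The effect of the exchange is less clear when compound 4 is set against the other two compounds, since a 1.9-fold higher number from compound 2 to compound 4 (0.28 log units; within the scatter) and a 1.6-fold lower number from compound 1 to compound 4 (0.20 log units; within the scatter) both leave compound 4 within the scatter of its neighbours, so methylamino cannot be told apart in this assay from ethylamino or from diethylamino. Nothing available beyond these numbers explains what the remaining hydrogen on that nitrogen does.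

From the compounds shown here alone, it stays open whether a longer chain such as propyl or butyl on that nitrogen, or a phenyl group there, would keep the number in this range. Also open, going by these compounds, is whether a plain amino group, with hydrogen in place of both alkyl groups, would take the number lower still.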